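Acid-bearing head groups on a weakly active series

The compounds below may be only part of what the source reports. "The series", "measured", "known", "first", "only" and "open" are said of these compounds alone.

Compound 1 `OC[C@@H](O[C@H]1CCCN(Cc2nc3ccccc3[nH]2)[C@H]1c1ccccc1)c1cc(Cl)cc(Cl)c1` and compound 2 `Cc1nc(C(=O)O)ccc1CN1CCC[C@H](O[C@H](CO)c2cc(Cl)cc(Cl)c2)[C@@H]1c1ccccc1` share the same core. In an assay on isolated protein for activation of cGMP-dependent protein kinase 1 (Homo sapiens), read by ADP-Glo, with stated times of 30 min and 2 h (on this read-out lower numbers stand for an effect already at smaller amounts and higher numbers for an effect only at larger amounts of compound), compound 1 gives only a limit of the assay, > 200000 nM. In this assay, for the measured compounds named here, compound 2 gives 144000 nM, the only measured number so far. The other value, that of compound 1, is a limit. Going by the values given here, the one measured step, an at least 1.3-fold lower number from compound 1 to compound 2 (0.14 log units; that floor lies within the scatter), is therefore bounded only from one side, since (the limit of > 200000 nM in this assay, at which 1 of the 2 values shown sits).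

Compound 3 `Cc1cc(C(=O)O)ccc1C(=O)N1CCC[C@H](O[C@H](CO)c2cc(Cl)cc(Cl)c2)[C@@H]1c1ccccc1` is the next member. It differs from compound 2 by a group of 12 heavy atoms (9 carbon, 3 oxygen; one six-membered aromatic ring of carbon only) in place of a group of 11 heavy atoms (8 carbon, 1 nitrogen, 2 oxygen; one six-membered aromatic ring with 1 hetero atom), on an amine nitrogen in a ring. The measured step from compound 1 to compound 2 altered the group on the saturated chain carbon bound to the ring amine nitrogen, the same region that changes here, and its size, an at least 1.3-fold lower number from compound 1 to compound 2 (0.14 log units; that floor lies within the scatter), is within the scatter. No step beyond the scatter is expected in this assay for compound 3, and the weak activity of compound 2, 144000 nM, is expected to carry over. For compound 3 there is a fair chance that only a limit is reported. Compound 3 is estimated at 150000 nM, with a range from 50000 nM to 400000 nM, which corresponds to the expected step of a 1.0-fold higher number from compound 2 to compound 3 (0.02 log units; within the scatter).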

Compound 3, half-maximal effective concentration: > 200000 nM
Compound 3 gave a limit, no number (the forecaster's own chance of this, stated with the estimate: 45%); middle value at least 1.3-fold (0.12 log units) away from the limit.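

In this assay, for the compounds shown here, the group with a six-membered aromatic ring of carbon only, set on the amine nitrogen in the ring in place of the group with a six-membered aromatic ring with 1 hetero atom, gives an at least 1.3-fold higher number from compound 2 to compound 3 (0.14 log units; that floor lies within the scatter); this is only a floor, so the position has so far yielded no step that can be sized. Compound 3, with its carboxylic acid retained on the new ring, gives only a limit of the assay, > 200000 nM, and the step between compound 1 and compound 3 cannot be read, as both values are limits. A real effect of this change at this position therefore stays hidden, because of where most of the values sit: the limit of > 200000 nM in this assay, at which 2 of the 3 values shown sit.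

The carbonyl bound to the amine nitrogen and the aromatic ring of carbon only enter together in compound 3, and no compound shown separates them. Also open, on these data alone, is whether an amine, or a longer chain carrying the carboxylic acid, on this nitrogen would give a number well clear of the limit in this assay.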